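Cyano for fluoro on the ketone aryl ring of compound 3

The source may hold more compounds than are shown below. What is called first, only, known or untested is meant among the compounds shown, and "the series" means these compounds.

Compound 1 `Cc1cc(=O)oc2cc(OCC(=O)c3ccc(C(C)(C)C)cc3)ccc12`: in a functional assay on MCF7 cells (Homo sapiens) for antiproliferative activity, with a stated time of 96 h (on this read-out lower numbers stand for stronger inhibition and higher numbers for weaker inhibition), compound 1 gives 20700 nM.
Compound 2 `Cc1cc(=O)oc2cc(OCC(=O)c3ccc4ccccc4c3)ccc12`: in this assay compound 2 gives > 100000 nM, which is a limit of the assay and not a number.
Compound 3 `Cc1cc(=O)oc2cc(OCC(=O)c3ccc(F)cc3)ccc12`: in this assay compound 3 gives > 100000 nM, again a limit of the assay rather than a number.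

Compound 3 therefore stands at the weak end of what has been measured, where only a limit is known, and it shares that position with compound 2; only compound 1 has given a number. Among the compounds with values here, the one measured step that reaches compound 3 is an at least 4.8-fold higher number from compound 1 to compound 3 (0.68 log units; beyond the scatter), so the fluoro group is tied to the weaker outcome, with the caveat (the limit of > 100000 nM in this assay, at which 2 of the 3 values shown sit).

Compound 4 `Cc1cc(=O)oc2cc(OCC(=O)c3ccc(C#N)cc3)ccc12` differs from compound 3 as follows: cyano in place of fluoro on an aromatic carbon. Within the data shown here, no measured step shows cyano in place of fluoro, so no direct guide exists for the size or direction of this change in this assay. With compound 3 already at a limit, and with compound 2 also at that limit, a step of an at least 1.1-fold lower number from compound 3 to compound 4 (0.04 log units; that floor lies within the scatter) is expected, which amounts to no clear change beyond the scatter. Compound 4 is therefore estimated at 90000 nM in this assay, within a range of 20000 nM to 400000 nM, with a substantial chance that only a limit is reported.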

Compound 4, half-maximal inhibitory concentration: > 100000 nM
Compound 4: no number, only a limit; the forecaster's own chance of this, stated with the estimate: 60%; middle value at least 1.1-fold (0.04 log units) from the limit.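

Cyano on this carbon, para to a large group, ends at the same limit of the assay as fluoro, so a second and different replacement has now failed to give a number, and the step between compound 3 and compound 4 cannot be read: the limit of > 100000 nM in this assay, at which 3 of the 4 values shown sit.

The comparison with compound 1 can be read, and in this assay cyano in place of tert-butyl gives an at least 4.8-fold higher number from compound 1 to compound 4 (0.68 log units; beyond the scatter). This sits alongside the earlier at least 4.8-fold higher number from compound 1 to compound 3 (0.68 log units; beyond the scatter), so both replacements of tert-butyl shown here lead to a limit, and compound 1 remains the only compound of the four with a number.

The compounds shown leave open whether a number at this position needs tert-butyl itself or whether another alkyl group, such as isopropyl or methyl, would also give one. They also leave open how a methoxy group or an amine on the same carbon would read out, and whether fluoro and cyano differ at all, since the true values of compound 3 and compound 4 remain hidden behind the limit.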